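Phenyl in place of dimethoxyphenyl on the biaryl amide

The compounds below may be only part of what the source reports. "The series", "measured", "known", "first", "only" and "open" are said of these compounds alone.

Compound 1 `COc1ccccc1N1CCN(CCCCC(=O)NCc2ccccc2-c2c(OC)cccc2OC)CC1` gives 32.4 nM in an assay on CHO-K1 cells for displacement of a labelled ligand from 5-hydroxytryptamine receptor 7 (Homo sapiens), read by scintillation counting; on this read-out lower numbers stand for stronger inhibition and higher numbers for weaker inhibition. This is the lowest of the three numbers recorded so far: compound 2 `COc1ccccc1N1CCN(CCCC(=O)NCc2ccccc2-c2ccccc2)CC1` gives 64.5 nM, which lies within the scatter of compound 1, while compound 3 `COc1ccccc1N1CCN(CCC(=O)NCc2ccccc2-c2ccccc2)CC1` gives 187 nM, beyond it. Compound 4 `COc1ccccc1N1CCN(CCCCC(=O)NCc2ccccc2-c2ccccc2)CC1` shares the core of compound 1 and differs from it in one place: phenyl in place of 2,6-dimethoxyphenyl on an aromatic carbon. Going by the values given here, no measured pair isolates this exchange. Compound 2 carries phenyl at this position and gives 64.5 nM, and compound 3 carries phenyl at this position and gives 187 nM, so phenyl alone does not preclude numbers in the range of compound 1. Compound 4 is expected to remain close to compound 1, with a 1.2-fold higher number from compound 1 to compound 4 (0.09 log units; within the scatter) estimated to stay within the scatter in either direction. The estimated value for compound 4 is 40 nM, with a range from 15 nM to 110 nM.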

Compound 4, inhibition constant: 37.9 nM
Estimate against measurement, compound 4: 1.1-fold (0.02 log units) above, and the stated range covers the measured number.
By their numbers in this assay, from the lowest: compounds 1, 4 and 2 (each within the scatter of the next); then compound 3.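

Phenyl in place of 2,6-dimethoxyphenyl gives a 1.2-fold higher number from compound 1 to compound 4 (0.07 log units; within the scatter) in this assay, the first pair to isolate this position. The two methoxy groups are therefore not needed to keep the number of compound 4 within the scatter of compound 1, and this ring accepts both the larger and the smaller group. No measurement at hand accounts for this result.

The compounds shown leave open whether an amine or a carboxylic acid on this ring would stay within the scatter as well. On these data alone, a single methoxy group at this ring also remains open.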